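The source may hold more compounds than are shown below. What is called first, only, known or untested is meant among the compounds shown, and "the series" means these compounds.

The three measured compounds share one core: compound 1 `COc1ccc(NC(=O)[C@@H]2Cc3ccc(OCC(=O)NO)cc3CN2C(=O)CNC(=O)OC(C)(C)C)cc1`, compound 2 `COc1ccc(NC(=O)[C@@H]2Cc3ccc(OCC(=O)NO)cc3CN2CCCc2ccccc2)cc1` and compound 3 `COc1ccc(NC(=O)[C@@H]2Cc3ccc(OCC(=O)NO)cc3CN2C(=O)[C@@H]2CCCN2)cc1`. In an assay on isolated protein for inhibition of histone deacetylase 8 (Homo sapiens), read by fluorescence, with a stated time of 30 min (a lower number here means a stronger inhibitor, a higher number a weaker inhibitor), compound 1 gives 514 nM. In this assay compound 2 gives 1720 nM, and compound 3 gives 481 nM. Among these numbers compound 1 stands second highest of three, its nearest neighbour being compound 3 and its furthest compound 2. The step of a 1.1-fold lower number from compound 1 to compound 3 (0.03 log units; within the scatter) lies within the scatter, whereas a 3.3-fold higher number from compound 1 to compound 2 (0.52 log units; beyond the scatter) is a modest weakening and a 3.6-fold lower number from compound 2 to compound 3 (0.55 log units; beyond the scatter) a modest strengthening.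

Compound 4 `COc1ccc(NC(=O)[C@@H]2Cc3ccc(OCC(=O)NO)cc3CN2C(=O)[C@@H](N)C(C)C)cc1` has not yet been measured. It differs from compound 1 in one place: 1-amino-2-methylpropyl in place of ((tert-butoxycarbonyl)amino)methyl on a carbonyl carbon. Within the data shown here, two measured steps bear on this. The step from compound 1 to compound 3 also removed the (tert-butoxycarbonyl)amino group and left a carbonyl carrying a free amine, and it stayed within the scatter. The step from compound 1 to compound 2 did away with the carbonyl altogether and cost a modest amount. Compound 4 keeps the carbonyl and a free amine, as compound 3 does, so a step no larger than the scatter is expected, a 1.0-fold lower number from compound 1 to compound 4 (0.01 log units; within the scatter). In this assay compound 4 is estimated at 500 nM, with a range from 250 nM to 1000 nM.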

Compound 4, half-maximal inhibitory concentration: 1020 nM
Estimate against measurement, compound 4: 2.0-fold (0.31 log units) below, outside the stated range (above it).
By their numbers in this assay, from the lowest: compounds 3, 1, 4 and 2 (each within the scatter of the next, the first and the last beyond it).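

Among these compounds, at this position on the carbonyl carbon, swapping one amine-bearing group for another is not neutral: in this assay there is a 2.1-fold higher number from compound 3 to compound 4 (0.33 log units; beyond the scatter), the first modest step among compounds that keep the carbonyl, so a carbonyl carrying a free amine does not by itself fix the number near that of compound 3. The change from the larger protected group stays within the scatter, with a 2.0-fold higher number from compound 1 to compound 4 (0.30 log units; within the scatter), yet only just at the edge of it, and a 1.7-fold lower number from compound 2 to compound 4 (0.23 log units; within the scatter) also lies within the scatter, so compound 4 cannot be told apart from compound 1 or from compound 2, although the latter has no carbonyl and earlier stood apart from the other two. Nothing given here accounts for these steps.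

The compounds shown leave open how an aminomethyl group on the same carbonyl carbon would read, which would set the free amine apart from the rest of the 1-amino-2-methylpropyl chain. They also leave open whether the opposite stereocentre in 1-amino-2-methylpropyl, or an acetamide in place of its free amine, would move the number in either direction.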